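The source may report more compounds than this note shows. Statements on the series, on what has been measured and on what is new or still open speak of the compounds shown alone.

Measured compounds:
compound 1, `CCCCCCCCCCCCCCCC(=O)N[C@@H](CCC(=O)O)CC(C)C`: 200 nM
compound 2, `CCCCCCCCCC(=O)N[C@@H](CC(=O)O)CC(C)C`: 1400 nM
compound 3, `CCCCCC/C=C/CC(=O)N[C@@H](CC(=O)O)CC(C)C`: 300 nM

These three compounds were tested in an assay on isolated protein with Group VII phospholipase A2 (Sus scrofa) as the target; on this read-out lower numbers stand for stronger inhibition and higher numbers for weaker inhibition. Compound 3 stands in the middle of the three numbers. Its gap to compound 1 lies within the usual scatter of repeated measurements, so the two cannot be told apart on these data. Its gap to compound 2 lies beyond the scatter, with compound 2 giving the weaker inhibition of the two.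

Compound 4, `CCCCCC/C=C/CC(=O)N[C@H](CSc1ccccc1)CC(=O)O`, has not yet been measured in this assay. It differs from compound 3 in one place: phenylsulfanyl in place of isopropyl on a saturated chain carbon, two bonds along the chain from an amide-type nitrogen. Going by the values given here, no measured pair in this set shows the effect of this kind of exchange, so there is no step to lean on. With nothing in the data pointing either way, the expectation is a step of no size beyond the scatter, no change at the digits printed from compound 3 to compound 4 (within the scatter). Compound 4 is therefore estimated at 300 nM in this assay, with a range from 80 nM to 1200 nM that reflects the lack of any comparable step among the measured compounds.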

Compound 4, half-maximal inhibitory concentration: 95 nM
Beside the measured number, compound 4's estimate is 3.2-fold (0.50 log units) above it; low and high end bracket the measured number.
By their numbers in this assay, from the lowest: compound 4; then compounds 1 and 3 (each within the scatter of the next); then compound 2.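

In this assay, putting phenylsulfanyl in place of isopropyl on a saturated chain carbon, two bonds along the chain from an amide-type nitrogen, gives a 3.2-fold lower number from compound 3 to compound 4 (0.50 log units; beyond the scatter), so the change goes with stronger inhibition. The earlier compounds shown here all carry isopropyl here and could say nothing about this position; this step shows that it accepts a larger group with a six-membered aromatic ring and a sulfur atom, and that inhibition does not suffer. No separate measurement explains why the number fell.

A single step cannot separate the part played by the sulfur from that of the ring, and a benzyl or phenoxymethyl group at this place would help to tell them apart. Also open, on these data alone, is how a cyclohexyl group, or a fluorine or methoxy group on the aromatic ring, would fare.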